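Swapping a Pyridine for Bromophenyl on a Hydrazone

A few compounds are considered here, and "the series" means these few. Any claim that something is new, unique, unknown or untested is made for them only; others in the source may bear on it.

The compounds share one core and differ mainly in the group carried by the hydrazone. In a functional assay on ECa-109 cells (Homo sapiens) for antiproliferative activity, read by MTT assay, with a stated time of 72 h (a lower number here means a stronger inhibitor, a higher number a weaker inhibitor), compound 1 `CCCSc1nc(N/N=C/c2cc(OC)c(OC)c(OC)c2)c2nnn(Cc3ccccc3)c2n1` gives 4060 nM, and compound 3 `CCCSc1nc(N/N=C(\C)c2ccccc2O)c2nnn(Cc3ccc(O)cc3)c2n1` gives 15900 nM. Compound 2 `CCCSc1nc(N/N=C/c2cccnc2)c2nnn(Cc3ccccc3)c2n1` reaches only the boundary of this assay, > 64000 nM, which is a limit rather than a measured number (the limit of > 64000 nM in this assay, at which 1 of the 3 values shown sits). Compound 4 `CCCSc1nc(N/N=C/c2ccc(Br)cc2)c2nnn(Cc3ccccc3)c2n1` is still unmeasured; it differs from compound 2 by 4-bromophenyl in place of pyridin-3-yl on a carbon with a double bond to nitrogen. Within the data shown here, since no pair of measured compounds shows this kind of change, the direction is uncertain, but a move toward the potency of compound 1 at 4060 nM is plausible, so a step of an at least 3.2-fold lower number from compound 2 to compound 4 (0.50 log units; beyond the scatter) toward stronger inhibition is expected. Compound 4 is therefore estimated at 20000 nM, within a range from 5000 nM to 64000 nM.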

Compound 4, half-maximal inhibitory concentration: > 64000 nM
Compound 4 was reported as a limit (the forecaster's own chance of this, stated with the estimate: 30%); middle value at least 3.2-fold (0.50 log units) away from the limit.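

Compound 2 and compound 4 both stop at a limit rather than a number, so the step between them cannot be read: the limit of > 64000 nM in this assay, at which 2 of the 4 values shown sit. The compounds shown leave open how 4-bromophenyl and pyridin-3-yl truly compare in this assay.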